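This account rests on a few compounds, and the source may have more. Where it says the series, first, only, none or still open, it means among the compounds named here.

Working notes on the series. Compound 1, `Clc1ccc(-c2cc3ccccc3[nH]2)cc1Cl`, in an assay on isolated protein for inhibition of Aromatase (Homo sapiens), read by fluorescence, using NADPH, with a stated time of 30 min, tested at 50 uM (a higher number here means more inhibition at the concentration tested (going by the name of the read-out), a lower number less inhibition), gives 22.7%. Within the data shown here, compound 2, `O=[N+]([O-])c1ccc2[nH]c(-c3ccc(Cl)c(Cl)c3)cc2c1`, in this assay gives 7.59%, the lower of the two numbers so far; the only measured step runs a number 15.1 percentage points lower from compound 1 to compound 2 (beyond the scatter), so compound 2 stands a clear step under compound 1. Compound 3, `Nc1ccc2[nH]c(-c3ccc(Cl)c(Cl)c3)cc2c1`, is not yet measured. It differs from compound 2 by amino in place of nitro on an aromatic carbon. Among the measured compounds shown here, the one step that bears on this change is the step from compound 1 to compound 2, in which a nitro group entered in place of hydrogen and the number fell by a modest amount beyond the scatter. Compound 3 removes that nitro group again, but puts an amino group in its place rather than hydrogen, so a full return to the level of compound 1 is not assumed; a partial return is expected. The step is therefore expected to be upward, of a size around a number 8.4 percentage points higher from compound 2 to compound 3 (within the scatter). For compound 3 in this assay the expected value is 16%, with a range from 4% to 30%.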

Compound 3, a percentage reported as inhibition, at one concentration (the size of the read-out at that concentration, not a potency): 21.4%
The estimate for compound 3 lay 5.4 percentage points below the measured number, and the stated range covers the measured number.
By their numbers in this assay, from the lowest: compound 2; then compounds 3 and 1 (each within the scatter of the next).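

In this assay, replacing nitro with amino on this aromatic carbon brings a clear gain (a number 13.8 percentage points higher from compound 2 to compound 3 (beyond the scatter)), so the drop seen with nitro does not extend to every group placed at this position. Amino in place of hydrogen gives a step that lies within the scatter (a number 1.3 percentage points lower from compound 1 to compound 3 (within the scatter)), so amino and hydrogen cannot be told apart here, and among the three compounds only nitro, in compound 2, stands apart from the others. Nothing on hand accounts for the difference between nitro and amino at this position.

From the compounds shown here alone, whether a hydroxyl, a methoxy or a carboxylic acid on this same carbon would fall with hydrogen and amino or with nitro remains open, as does whether amino would behave the same way on another carbon of the ring. Going by these compounds, all of these numbers come from a single tested concentration, so they show only the size of the effect at that concentration, and how compound 1 and compound 3 would compare at any other concentration also remains open.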